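Swapping the acid-bearing ring on a kinase activator

This account rests on a few compounds, and the source may have more. Where it says the series, first, only, none or still open, it means among the compounds named here.

Three compounds share one core and differ only in the group attached to the ring amine. Compound 1 `OC[C@@H](O[C@H]1CCCN(Cc2ncc[nH]2)[C@H]1c1ccccc1)c1cc(Cl)cc(Cl)c1` gives 47000 nM in an assay on isolated protein for activation of cGMP-dependent protein kinase 1 (Homo sapiens), read by ADP-Glo, with stated times of 30 min and 2 h, in the presence of a further agent that is not named here; on this read-out lower numbers stand for an effect already at smaller amounts and higher numbers for an effect only at larger amounts of compound. Compound 2 `Cc1cc(C(=O)O)ccc1C(C)N1CCC[C@H](O[C@H](CO)c2cc(Cl)cc(Cl)c2)[C@@H]1c1ccccc1` gives 18000 nM in this assay, a 2.6-fold lower number from compound 1 to compound 2 (0.42 log units; beyond the scatter). Compound 3 `O=C(O)c1ccc2nc(CN3CCC[C@H](O[C@H](CO)c4cc(Cl)cc(Cl)c4)[C@@H]3c3ccccc3)[nH]c2c1` gives 380 nM, a 120-fold lower number from compound 1 to compound 3 (2.09 log units; beyond the scatter), and so compound 3 holds the lowest number of the three, clearly apart from both others.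

Compound 4 `Cc1nc(C(=O)O)ccc1CN1CCC[C@H](O[C@H](CO)c2cc(Cl)cc(Cl)c2)[C@@H]1c1ccccc1` has not been measured. It differs from compound 3 by a group of 10 heavy atoms (7 carbon, 1 nitrogen, 2 oxygen; one six-membered aromatic ring with 1 hetero atom) in place of a group of 12 heavy atoms (8 carbon, 2 nitrogen, 2 oxygen; one five-membered aromatic ring with 2 hetero atoms, one six-membered aromatic ring of carbon only), on a saturated chain carbon bound to an amine nitrogen in a ring. Both measured steps bear on this change: the large gain a 120-fold lower number from compound 1 to compound 3 (2.09 log units; beyond the scatter) came with a carboxylic acid on a five-membered aromatic ring with 2 hetero atoms joined to a six-membered aromatic ring of carbon only, whereas the modest gain a 2.6-fold lower number from compound 1 to compound 2 (0.42 log units; beyond the scatter) came with a carboxylic acid on a single six-membered ring. The group entering compound 4 is again a single six-membered ring carrying a carboxylic acid, nearer in size to that of compound 2. The number is therefore expected to rise from compound 3, an estimated 7.9-fold higher number from compound 3 to compound 4 (0.90 log units; beyond the scatter). Compound 4 is estimated at 3000 nM, with a range of 800 nM to 12000 nM.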

Compound 4, half-maximal effective concentration: 370 nM
For compound 4 the middle estimate is 8.1-fold (0.91 log units) above the measured one; the whole stated range lies above it.
By their numbers in this assay, from the lowest: compounds 4 and 3 (each within the scatter of the next); then compound 2; then compound 1.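

In this assay, the single six-membered aromatic ring with 1 hetero atom serves at this place as well as the larger group with two aromatic rings, with a 1.0-fold lower number from compound 3 to compound 4 (0.01 log units; within the scatter) and no real difference between them. A single ring with a carboxylic acid does not by itself secure this result, as compound 2 also has one, yet there is a 49-fold lower number from compound 2 to compound 4 (1.69 log units; beyond the scatter) in favour of the group in compound 4, while a 130-fold lower number from compound 1 to compound 4 (2.10 log units; beyond the scatter) shows a gain as large as that seen for compound 3. No measurement shown here explains these differences.

The step from compound 2 changes more than one feature of the group, so it cannot show which feature matters. Going by these compounds, it also remains open whether an amide in place of the carboxylic acid on the ring of compound 4 would keep this number.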